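This account rests on a few compounds, and the source may have more. Where it says the series, first, only, none or still open, it means among the compounds named here.

For the measured compounds named here, compound 1 `Nc1cc(N)c2nc(-c3ccccc3)c(NCc3ccc(Cl)c(Cl)c3)nc2c1` is the one member of this small set with a definite number in a functional assay on 786-0 cells (Homo sapiens) for inhibition, read by sulforhodamine B assay, with a stated time of 48 h; a lower number here means a stronger inhibitor of growth, a higher number a weaker inhibitor of growth: compound 1 gives 30200 nM. Two related compounds share its core. Compound 2 `CCOC(=O)[C@H](CCC(=O)O)NC(=O)c1ccc(Sc2nc3cc(N)cc(N)c3nc2-c2ccccc2)cc1` reaches only a limit of the assay in this assay, reported as < 100000 nM. Compound 3 `CCOC(=O)[C@H](CCC(=O)O)NC(=O)c1ccc(Oc2nc3cc(N)cc(N)c3nc2-c2ccccc2)cc1` likewise stops at a limit in this assay, reported as < 50200 nM. Those two limits are not numbers and say nothing about how either compound compares with compound 1.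

Compound 4 `COc1ccc(CNc2nc3cc(N)cc(N)c3nc2-c2ccccc2)cc1` has not yet been measured. It differs from compound 1 in one place: 4-methoxyphenyl in place of 3,4-dichlorophenyl on a saturated chain carbon bound to a nitrogen on an aromatic ring. Going by the values given here, no pair of measured compounds shows the effect of such an exchange, so nothing here fixes the direction of the step. With a single firm number to rest on, the expectation is a step of a 1.3-fold higher number from compound 1 to compound 4 (0.12 log units; within the scatter), one that would stay within the usual scatter of this assay. Compound 4 is therefore estimated at 40000 nM, with a range from 12000 nM to 100000 nM.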

Compound 4, concentration for total growth inhibition: 41700 nM
Beside the measured number, compound 4's estimate is 1.0-fold (0.02 log units) below it, within the range that was stated.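

For the compounds shown here, the exchange of 3,4-dichlorobenzyl for 4-methoxybenzyl is the first change at this place that can be read, and in this assay it amounts to a 1.4-fold higher number from compound 1 to compound 4 (0.14 log units; within the scatter). The two chlorine atoms can therefore give way to a methoxy group, which adds a hydrogen-bond acceptor, without a change this assay can tell apart from scatter. With compound 4, the shared core also has a second definite number. Nothing measured among these compounds explains why the number holds steady across this exchange.

A single exchange cannot show how much change this place accepts in general. The compounds shown leave open what a carboxylic acid or an amine in place of the methoxy group, or a longer chain in place of the benzyl group, would do.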